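Methoxy on the cyclobutyl ring and volume of distribution

A few compounds are considered here, and "the series" means these few. Any claim that something is new, unique, unknown or untested is made for them only; others in the source may bear on it.

In an ADME assay (Rattus norvegicus, strain Wistar Han) for pharmacokinetics (on this read-out higher numbers stand for wider distribution into tissues and lower numbers for narrower distribution), three compounds have been measured:

compound 1 `CCn1c(-c2cnc(C)nc2)nc2c(N[C@H]3CCN(C(=O)[C@H]4C[C@@H](OC)C4)C3)ncnc21`: 4.1 L/kg
compound 2 `CCn1c(-c2cnc(C)nc2)nc2c(O[C@H]3CCN(C(=O)C4CCC4)C3)ncnc21`: 4 L/kg
compound 3 `CCn1c(-c2cnc(C)nc2)nc2c(N[C@H]3CCN(C(=O)C4CCC4)C3)ncnc21`: 9.2 L/kg

Compound 3 and compound 1 share one core and differ in a single place, (methoxy in place of hydrogen on a saturated ring carbon); this change produced a 2.2-fold lower number from compound 3 to compound 1 (0.35 log units; beyond the scatter). Compound 2 has the lowest of the three numbers, but its number and that of compound 1 are within the scatter of each other, so no order between those two can be read. The difference between the core of compound 2 and the core of compound 3 is not broken down here; what is clear is that compound 3 stands beyond the scatter above both of the others.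

The unmeasured compound 4 `CCn1c(-c2cnc(C)nc2)nc2c(O[C@H]3CCN(C(=O)[C@H]4C[C@@H](OC)C4)C3)ncnc21` is built on the core of compound 2 and differs from it in one place, (methoxy in place of hydrogen on a saturated ring carbon). This is the same change that was made from compound 3 to compound 1, at the same place on the four-membered ring, and it occurs twice among the compounds shown. The account has one precedent and one only; whether it carries over from the core of compound 3 to the core of compound 2 is not known. Since compound 2 already starts lower, a step of the same direction is expected, and it is estimated at a 1.8-fold lower number from compound 2 to compound 4 (0.26 log units; within the scatter), resting on the step from compound 3 to compound 1 of a 2.2-fold lower number from compound 3 to compound 1 (0.35 log units; beyond the scatter). For compound 4 the expected number in this assay is therefore 2.2 L/kg, estimated to fall between 1.3 L/kg and 4 L/kg.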

Compound 4, volume of distribution: 2.5 L/kg
The estimate for compound 4 lay 1.1-fold (0.06 log units) below the measured number; the measured number falls inside the stated range.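

In this assay, replacing hydrogen with methoxy on a saturated ring carbon of the four-membered ring, which turns cyclobutylcarbonyl into (3-methoxycyclobutyl)carbonyl, gave a 1.6-fold lower number from compound 2 to compound 4 (0.20 log units; within the scatter), so on the core of compound 2 this step taken alone cannot be told apart from the scatter. Set beside the earlier step, it shows no difference between the two cores that can be read: the same change on two cores in this assay, a 2.2-fold lower number (0.35 log units; beyond the scatter) from compound 3 to compound 1 and a 1.6-fold lower number (0.20 log units; within the scatter) from compound 2 to compound 4, 1.4-fold (0.15 log units) apart, within the scatter of two such steps. Among these compounds, the two steps thus run in the same direction and are compatible with the change carrying over, but they are only two pairs, one of them within the scatter, and they establish neither a fixed size for the step nor that it would hold on any further core.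

The compounds shown leave open how other groups at the same place on the cyclobutyl ring, such as a hydroxyl, a fluorine or an amine, or a longer ether chain in place of methoxy, would compare with methoxy in this assay. They also leave open whether methoxy set on the other face of the four-membered ring would give a step like these two.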